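Adding a second methyl to compound 2

The source may hold more compounds than are shown below. What is called first, only, known or untested is meant among the compounds shown, and "the series" means these compounds.

compound 1 `COC(=O)NC1=NC(c2ccccc2C)CN1`: 55 mg/kg
compound 2 `COC(=O)NC1=NC(c2cccc(C)c2)CN1`: 100 mg/kg
compound 3 `COC(=O)NC1=NC(c2cccc(Cl)c2)CN1`: 48 mg/kg

In a functional assay on the whole organism for antagonist activity, with Mus musculus as the target, in the maximal electroshock model (on this read-out higher numbers stand for an effect only at larger amounts of compound and lower numbers for an effect already at smaller amounts), compound 2 at 100 mg/kg lies within the scatter of compound 1, while compound 3 stands lower, with a 2.1-fold lower number from compound 2 to compound 3 (0.32 log units; beyond the scatter) as the measured step. Compound 4 `COC(=O)NC1=NC(c2cc(C)ccc2C)CN1` is compound 2 with methyl in place of hydrogen on an aromatic carbon, ortho to a large group and para to a methyl group (methyl in place of hydrogen on an aromatic carbon). That one measured step swaps chloro for methyl, so it bears only loosely on this change. Compound 1 at 55 mg/kg also carries a methyl ortho to a large group. In this assay no step beyond the scatter is therefore expected. The expected step is a 1.5-fold lower number from compound 2 to compound 4 (0.19 log units; within the scatter) on this reasoning. For compound 4 the estimated value is 65 mg/kg with an expected range from 32 mg/kg to 130 mg/kg in this test.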

Compound 4, dose for half-maximal effect: about 100 mg/kg
Beside the measured number, compound 4's estimate is 1.5-fold (0.19 log units) below it, within the range that was stated.
By their numbers in this assay, from the lowest: compounds 3, 1, 2 and 4 (each within the scatter of the next, the first and the last beyond it).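

In this assay this methyl, ortho to a large group and para to a methyl group, gives no change at the digits printed from compound 2 to compound 4 (within the scatter) and so shows that a second methyl on the ring need not shift the number. Approached from the other methyl compound, the same change gives a 1.8-fold higher number from compound 1 to compound 4 (0.26 log units; within the scatter) and so also stays short of a step beyond the scatter. Nothing given here explains this outcome.

Going by these compounds, whether a chloro, methoxy or amine at this place would behave as methyl does remains open.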